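Bromo for Fluoro on a Shorter Linker

The source may report more compounds than this note shows. Statements on the series, on what has been measured and on what is new or still open speak of the compounds shown alone.

Of the compounds shown here, three have been measured in a functional assay on HCT-116 cells (Homo sapiens) for inhibition, read by sulforhodamine B assay, with a stated time of 48 h, tested at 50 uM; on this read-out lower numbers stand for less inhibition of growth and higher numbers for more inhibition of growth at the one concentration tested. Compound 1 `O=C1C(=O)N(CCCCCn2cc(COc3cc(=O)oc4ccccc34)nn2)c2ccc(F)cc21` gives 59% in this assay. Compound 2 `O=C1C(=O)N(CCCCCn2cc(COc3cc(=O)oc4ccccc34)nn2)c2ccc(Br)cc21` differs from compound 1 only in the change (bromo in place of fluoro on an aromatic carbon). In this assay compound 2 gives 43%. This change made a step of a number 16 percentage points lower from compound 1 to compound 2 (beyond the scatter). Compound 3 `O=C1C(=O)N(CCCn2cc(COc3cc(=O)oc4ccccc34)nn2)c2ccc(F)cc21` carries a shorter chain between the two ring systems; how its core differs from the core of compound 1 is not broken down here. In this assay compound 3 gives 75%, the highest of the three numbers, standing above compound 1 and further above compound 2.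

Compound 4 `O=C1C(=O)N(CCCn2cc(COc3cc(=O)oc4ccccc34)nn2)c2ccc(Br)cc21` has not yet been measured. It stands to compound 3 as compound 2 stands to compound 1: the change is bromo in place of fluoro on an aromatic carbon, and the place where it occurs is described in the same words as for the pair of compound 1 and compound 2, so it is the same change rather than merely the same kind. That change has been seen once before in this set, where it lowered the number from compound 1 to compound 2 by a modest amount beyond the scatter. If the same change behaves in the same way on the core of compound 3, a step of about a number 16 percentage points lower from compound 3 to compound 4 (beyond the scatter) is expected from compound 3 to compound 4, resting on the single earlier step of a number 16 percentage points lower from compound 1 to compound 2 (beyond the scatter). On that basis compound 4 is estimated to give 59% in this assay, with a range of roughly 45% to 72%, since a single precedent leaves the size of the step uncertain.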

Compound 4, percent growth inhibition at one concentration: 66%
Compound 4: the middle estimate sits 7 percentage points below what was measured; low and high end bracket the measured number.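

On the core of compound 3, the step for bromo in place of fluoro on an aromatic carbon in this assay is a number 9 percentage points lower from compound 3 to compound 4 (within the scatter), whereas the same change on the core of compound 1 gave a step that lay beyond the scatter. The two steps point the same way on paper, yet their sizes cannot be told apart: the same change on two cores in this assay, a number 16 percentage points lower (beyond the scatter) from compound 1 to compound 2 and a number 9 percentage points lower (within the scatter) from compound 3 to compound 4, 7 percentage points apart, within the scatter of two such steps

The change therefore carried from one core to the other without a measurable difference in the size of its step, but this does not show that the step is constant, since one step alone lies within the scatter and the comparison rests on just two pairs of compounds, each read at a single concentration on one cell line.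

The compounds shown leave open how other groups on that aromatic carbon, such as chloro, methoxy or a nitrile, would read against fluoro and bromo. They also leave open whether the two steps would still match on a core with a longer chain, or on a core in which the triazole-linked part carries an amine or a carboxylic acid.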